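The source may hold more compounds than are shown below. What is called first, only, known or untested is meant among the compounds shown, and "the series" means these compounds.

Measured compounds:
compound 1, `CNC(=O)/C=C/c1ccncc1-c1ccc2ccccc2c1`: 8680 nM
compound 2, `CNC(=O)/C=C/c1ccncc1-c1ccc2c(ccn2C)c1`: 8550 nM
compound 3, `CNC(=O)/C=C/c1ccncc1-c1ccc2[nH]ccc2c1`: > 10000 nM

All three were tested in a functional assay on MDA-MB-231 cells (Homo sapiens) for inhibition, read by sulforhodamine B assay, with a stated time of 72 h; on this read-out higher numbers stand for weaker inhibition of growth and lower numbers for stronger inhibition of growth. Compound 1 gives 8680 nM and compound 2 gives 8550 nM, which sit within the usual scatter of one another, so compound 1 has the higher of the two numbers only nominally. For compound 3 the value > 10000 nM is a limit of the assay, not a number (the limit of > 10000 nM in this assay, at which 1 of the 3 values shown sits). Going by the values given here, the one step among measured compounds, an at least 1.1-fold higher number from compound 2 to compound 3 (0.06 log units; that floor lies within the scatter), swaps hydrogen for methyl on an aromatic nitrogen in the core and reaches only the limit.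

Compound 4, `O=C(/C=C/c1ccncc1-c1ccc2ccccc2c1)NC1CC1`, has not yet been measured in this assay. It differs from compound 1 by cyclopropyl in place of methyl on an amide-type nitrogen. Among the compounds with values here, no measured step touches the amide-type nitrogen, so the measured steps give no direct guide to this change. Compound 4 is therefore expected to land near compound 1 at 9000 nM, with a range from 3500 nM to 25000 nM. The estimated step of a 1.0-fold higher number from compound 1 to compound 4 (0.02 log units; within the scatter) is expected to stay within the scatter.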

Compound 4, concentration for 50% growth inhibition: 8420 nM
Compound 4: middle estimate off by 1.1-fold (0.03 log units), on the high side; measured number inside the range.
By their numbers in this assay, from the lowest: compounds 4, 2 and 1 (each within the scatter of the next). At a limit, above all of these: compound 3.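

In this assay, going by these compounds alone, this is the first change read at the amide-type nitrogen, and both compounds give real numbers rather than a limit. Cyclopropyl in place of methyl brings in more carbon and a three-membered ring, yet it gives a 1.0-fold lower number from compound 1 to compound 4 (0.01 log units; within the scatter) and so leaves growth inhibition unchanged within the usual scatter. Nothing available explains why this change makes so little difference.

On these data alone, it remains open whether this nitrogen would accept other groups just as readily, such as a longer chain, a phenyl ring or a chain ending in an amine. As far as these compounds go, it is also open whether the amide hydrogen matters, a question that a second methyl on this nitrogen would address.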